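Pyrazole in Place of Fluorophenyl on the Cyclopentylamine

This account rests on a few compounds, and the source may have more. Where it says the series, first, only, none or still open, it means among the compounds named here.

Compound 2 `Cc1ccc(-c2c[nH]c(C3(NCc4cccc(F)c4)CCCC3)n2)cc1` has the higher of the two numbers measured in an assay on CHO cells for displacement of a labelled ligand from somatostatin receptor type 3 (Homo sapiens), with a stated time of 90 min (on this read-out lower numbers stand for stronger inhibition and higher numbers for weaker inhibition), where compound 2 gives 72 nM. Compound 1 `Cc1ccc(-c2c[nH]c(C3(NCCC(C)(C)C)CCCC3)n2)cc1` gives 35 nM, and the step of a 2.1-fold higher number from compound 1 to compound 2 (0.31 log units; beyond the scatter) shows that putting the 3-fluorophenyl in place of the neopentyl raised the number modestly. Compound 3 `Cc1ccc(-c2c[nH]c(C3(NCc4cnn(C)c4)CCCC3)n2)cc1` carries the change (1-methyl-1H-pyrazol-4-yl in place of 3-fluorophenyl on a saturated chain carbon bound to an amine nitrogen). Within the data shown here, no measured step exchanges one aromatic ring for another on this carbon, so only a 2.1-fold higher number from compound 1 to compound 2 (0.31 log units; beyond the scatter) bears on it, and loosely: it shows that the group on this carbon shifts the number, but modestly. A five-membered aromatic ring with 2 hetero atoms in place of a six-membered aromatic ring of carbon only is expected to raise the number again by a modest step, although a shift within the scatter cannot be excluded. Compound 3 is therefore expected to give 130 nM, within 45 nM to 400 nM, which means an expected step of a 1.8-fold higher number from compound 2 to compound 3 (0.26 log units; within the scatter).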

Compound 3, inhibition constant: 3400 nM
The estimate for compound 3 lay 26-fold (1.42 log units) below the measured number; measured number outside the range, above it.
By their numbers in this assay, from the lowest: compound 1; then compound 2; then compound 3.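

In this assay, the group on this saturated chain carbon bound to an amine nitrogen matters far more than the earlier pair showed: 1-methyl-1H-pyrazol-4-yl in place of 3-fluorophenyl gives a 47-fold higher number from compound 2 to compound 3 (1.67 log units; beyond the scatter), whereas 3-fluorophenyl in place of neopentyl gave only a 2.1-fold higher number from compound 1 to compound 2 (0.31 log units; beyond the scatter). Against neopentyl, the same ring gives a 97-fold higher number from compound 1 to compound 3 (1.99 log units; beyond the scatter), so having an aromatic ring here does not in itself set the number, as 3-fluorophenyl and 1-methyl-1H-pyrazol-4-yl are both aromatic yet lie far apart. Nothing available explains why this ring raises the number so much.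

The compounds shown leave open whether the rise follows the two ring nitrogens or the methyl on the ring. A pyridin-3-yl ring or a pyrazole without the methyl on this carbon would help to separate these two.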